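This account rests on a few compounds, and the source may have more. Where it says the series, first, only, none or still open, it means among the compounds named here.

Of the compounds shown here, three have been measured so far in a functional assay on MCF-12A cells (Homo sapiens) for inhibition; on this read-out lower numbers stand for stronger inhibition and higher numbers for weaker inhibition. Compound 1 `O=C(/C=C/c1ccc(I)cc1)c1ccc(OCB(O)O)cc1` gives 100000 nM. Compound 2 `O=C(/C=C/c1ccc(F)c(Cl)c1)c1ccc(B(O)O)cc1` gives 22000 nM, and compound 3 `O=C(/C=C/c1ccc(F)c(F)c1)c1ccc(B(O)O)cc1` gives 39000 nM. Within the data shown here, the only pair of measured compounds that differ in a single place is compound 2 and compound 3, where fluoro replaces chloro on an aromatic carbon, and that step is a 1.8-fold higher number from compound 2 to compound 3 (0.25 log units; within the scatter). Compound 1 stands with the highest number of the three; compound 3 is the nearer of the other two and compound 2 the further, and both gaps lie beyond the scatter.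

Compound 4 `O=C(O)COc1ccc(C(=O)/C=C/c2ccc(I)cc2)cc1` differs from compound 1 in one place: a group of 3 heavy atoms (1 carbon, 2 oxygen; no ring) in place of a group of 3 heavy atoms (1 boron, 2 oxygen; no ring), on a saturated chain carbon bound to an oxygen on an aromatic ring. Among the measured compounds shown here, no measured step bears on this change, since the one step available concerns a halogen exchange on an aromatic carbon and says nothing about the group exchanged here. In the absence of any guidance, compound 4 is expected to show no step beyond the scatter, no change at the digits printed from compound 1 to compound 4 (within the scatter). Compound 4 is accordingly estimated at 100000 nM, within a range from 35000 nM to 300000 nM.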

Compound 4, half-maximal inhibitory concentration: 38000 nM
Compound 4: the middle estimate sits 2.6-fold (0.42 log units) above what was measured; the range from low to high includes it.
By their numbers in this assay, from the lowest: compounds 2, 4 and 3 (each within the scatter of the next); then compound 1.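

In this assay, carboxy in place of the boron-bearing group, on a saturated chain carbon bound to an oxygen on an aromatic ring, gives a modest gain in inhibition (a 2.6-fold lower number from compound 1 to compound 4 (0.42 log units; beyond the scatter)). Among these compounds, the earlier compounds offered only a halogen exchange on an aromatic carbon, so this is the first sign that the group at this place affects the read-out, and here the step lies beyond the scatter. No measurement shown here offers an explanation for this step.

The compounds shown leave open whether an amide, a primary amine or a longer chain carrying the carboxy group would do better or worse at this place. They also leave open whether the same exchange would give a similar step alongside the chloro and fluoro substituents of compound 2 and compound 3.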